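Three Aryl Groups Behave Alike; a Fourth Is Tested

The source may hold more compounds than are shown below. What is called first, only, known or untested is meant among the compounds shown, and "the series" means these compounds.

Three compounds of a shared core have so far been measured in a functional assay on PC-12 cells (Rattus norvegicus) for cytotoxicity, read by MTT assay, with stated times of 2 h and 24 h, tested at 10 uM; on this read-out higher numbers stand for a stronger effect at the one concentration tested and lower numbers for a weaker effect:

compound 1, `Oc1cc(C(F)(F)F)ccc1-c1nc(-c2ccccc2O)n(-c2ccc(Br)cc2)n1` — compound 1 gives 100%
compound 2, `Oc1cc(C(F)(F)F)ccc1-c1nc(-c2ccccc2O)n(-c2ccc(C(F)(F)F)cc2)n1` — compound 2 gives 102%
compound 3, `Oc1cc(C(F)(F)F)ccc1-c1nc(-c2ccccc2O)n(-c2cccc(Cl)c2)n1` — compound 3 gives 100%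

Compound 3 stands level with compound 1 at the digits printed, the two together the lowest of the three numbers; its nearest neighbour is compound 1, with no change at the digits printed from compound 1 to compound 3 (within the scatter), and its furthest is compound 2, with a number 2 percentage points lower from compound 2 to compound 3 (within the scatter). Every step among the three lies within the scatter, including a number 2 percentage points higher from compound 1 to compound 2 (within the scatter).

Compound 4, `Oc1cc(C(F)(F)F)ccc1-c1nc(-c2ccccc2O)n(-c2ccc(F)cc2F)n1`, is not yet measured. It differs from compound 3 in one place: 2,4-difluorophenyl in place of 3-chlorophenyl on an aromatic nitrogen.

All three measured steps bear on this change, since each also exchanges one aryl group for another on the same aromatic nitrogen, and none of them moved the read-out beyond the scatter. The new group is again an aryl ring of carbon only with halogens on it. It is therefore expected that no change at the digits printed from compound 3 to compound 4 (within the scatter) will show no change beyond the scatter in this assay .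

Compound 4 is estimated at 100% in this assay , with a range from 90% to 110%.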

Compound 4, a percentage reported as activity, at one concentration (the size of the read-out at that concentration, not a potency): 97.9%
The estimate for compound 4 lay 2.1 percentage points above the measured number; measured number inside the range.
By their numbers in this assay, from the lowest: compounds 4, 1, 3 and 2 (each within the scatter of the next).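

With compound 4, the aryl group on the aromatic nitrogen becomes 2,4-difluorophenyl, and in this assay all three comparisons stay within the scatter: a number 2.1 percentage points lower from compound 3 to compound 4 (within the scatter), a number 2.1 percentage points lower from compound 1 to compound 4 (within the scatter) and a number 4.1 percentage points lower from compound 2 to compound 4 (within the scatter). Within the data shown here, this extends what the earlier compounds showed, as the read-out at this position now holds for fluorine as the halogen and for a ring bearing substituents at both of the numbered places in its name, not only for the 3-chlorophenyl, 4-bromophenyl and 4-(trifluoromethyl)phenyl groups. No measurement is available that would account for this lack of separation among the four groups.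

As far as these compounds go, all the groups compared at this position are phenyl rings with halogen or trifluoromethyl substituents, so it remains open whether an amine or a carboxylic acid on the ring, or a longer alkyl chain in place of the ring, would move the number beyond the scatter. From the compounds shown here alone, the two hydroxyl groups and the trifluoromethyl group on the shared core are the same in all four compounds, so what happens when they are changed also remains open.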